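Mirror-image Ureas Tested on Rice

A few compounds are considered here, and "the series" means these few. Any claim that something is new, unique, unknown or untested is made for them only; others in the source may bear on it.

Two ureas have been measured in an ADME assay on the whole organism with Oryza sativa as the target, tested at 0.1 uM; on this read-out lower numbers stand for a stronger effect and higher numbers for a weaker effect at the one concentration tested. Compound 1 `C[C@H](NC(=O)Nc1cccc(F)c1)c1ccccc1` gives 97%, and compound 2 `C[C@@H](NC(=O)Nc1ccc(F)c(F)c1)c1ccccc1` gives 99%. In this assay compound 2 and compound 1 stand within the scatter of each other, so the two numbers cannot be told apart; both lie near the top of the scale, where the effect is weak. Compound 3 `C[C@H](NC(=O)Nc1ccc(F)c(F)c1)c1ccccc1` is the next compound to be measured. It differs from compound 2 as follows: the two compounds have the same atoms and bonds and differ only in configuration as drawn: 1 of 1 stereo elements differ; a stereocentre at a saturated chain carbon is drawn R in compound 2 and S in compound 3. Because compound 1 gives 97% and compound 2 gives 99%, two numbers that already agree within the scatter, and compound 3 is the mirror image of compound 2 with every atom and bond kept, no step beyond the scatter is expected from compound 2 to compound 3. The estimate for compound 3 is therefore 97%, with a range from 88% to 100%, meaning an expected step of a number 2 percentage points lower from compound 2 to compound 3 (within the scatter).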

Compound 3, a percentage reported as activity, at one concentration (the size of the read-out at that concentration, not a potency): 99%
For compound 3 the middle estimate is 2 percentage points below the measured one; the measured number falls inside the stated range.
By their numbers in this assay, from the lowest: compounds 1, 2 and 3 (each within the scatter of the next).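

In this assay, reversing the stereocentre at the saturated chain carbon gives no change at the digits printed from compound 2 to compound 3 (within the scatter), the first direct test of handedness in this series. Fluoro in place of hydrogen on an aromatic carbon, with no change in configuration, gives a number 2 percentage points higher from compound 1 to compound 3 (within the scatter), so this change can now be read apart from the stereocentre, which the comparison of compound 1 with compound 2 could not do. The comparison of compound 2 with compound 3 speaks to handedness alone, and neither change shifts the read-out beyond the scatter; that reading rests on this: the fact that compounds 2 and 3 differ only in the configuration as drawn.

Going by these compounds, it remains open whether handedness would matter in a compound with a stronger effect, since all three lie near the weak end of the scale. It is also unknown whether a larger change to the shared core, such as adding an amine or a carboxylic acid, would move the number at all.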